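Fluoro on the phenyl of compound 1

The source may report more compounds than this note shows. Statements on the series, on what has been measured and on what is new or still open speak of the compounds shown alone.

Compound 1 `Clc1ccc(OC(CCn2ccnc2)c2ccccc2)c(Cl)c1` gives 96700 nM in a functional assay on K562 cells (Homo sapiens) for cytotoxicity (a lower number here means that less compound is tolerated, a higher number that more compound is tolerated), the second highest of the three numbers; compound 2 `Clc1ccc(OC(CCn2ccnc2)c2ccccc2)cc1` gives 221000 nM and compound 3 `FC(F)(F)c1ccc(OC(CCn2ccnc2)c2ccccc2)cc1` gives 71000 nM. The steps among them are a 2.3-fold higher number from compound 1 to compound 2 (0.36 log units; beyond the scatter) and a 3.1-fold lower number from compound 2 to compound 3 (0.49 log units; beyond the scatter), both of modest size and both on the dichlorinated ring of the shared core. Compound 4 `Fc1ccc(C(CCn2ccnc2)Oc2ccc(Cl)cc2Cl)cc1` differs from compound 1 by fluoro in place of hydrogen on an aromatic carbon, on the other six-membered aromatic ring of carbon only, para to a large group, so that phenyl becomes 4-fluorophenyl. For the measured compounds named here, none of the measured steps touches that ring, so the two steps give no direct guide; they show only that changes of one small aromatic substituent have shifted this assay by modest amounts. With nothing pointing in either direction, compound 4 is expected to lie close to compound 1, a step of a 1.1-fold lower number from compound 1 to compound 4 (0.03 log units; within the scatter), within the scatter. The estimate for compound 4 in this assay is 90000 nM, with a range from 40000 nM to 200000 nM.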

Compound 4, half-maximal cytotoxic concentration: 33500 nM
Beside the measured number, compound 4's estimate is 2.7-fold (0.43 log units) above it; the measured number lies below the stated range.
By their numbers in this assay, from the lowest: compound 4; then compounds 3 and 1 (each within the scatter of the next); then compound 2.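

In this assay the phenyl of the shared core turns out not to be a silent part of the molecule: with phenyl changed to 4-fluorophenyl, the result is a 2.9-fold lower number from compound 1 to compound 4 (0.46 log units; beyond the scatter) and this step lies beyond the scatter. Until now, only changes on the dichlorinated ring had been seen to move this number, and this step shows that the other ring responds as well, with a single fluorine atom on an aromatic carbon enough to produce a modest shift. No measurement at hand offers a reason for this shift.

As far as these compounds go, whether chloro, methoxy, an amine or a carboxylic acid in the same place would move the number the same way remains open. So does whether 4-fluorophenyl would have the same effect alongside the ring substituents of compound 2 or compound 3.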